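A nitro group added to compound 2

A few compounds are considered here, and "the series" means these few. Any claim that something is new, unique, unknown or untested is made for them only; others in the source may bear on it.

In a functional assay on A549 cells (Homo sapiens) for inhibition, with a stated time of 72 h (on this read-out higher numbers stand for weaker inhibition and lower numbers for stronger inhibition), compound 1 (`CNC(=O)C1=C[C@@H]2[C@@H](C(C)C)CC[C@@]3(CO3)[C@H]2C(=O)OC1`) gives 5540 nM and compound 2 (`CC(C)[C@H]1CC[C@@]2(CO2)[C@H]2C(=O)OCC(C(=O)OCc3ccc(-c4ccccc4)o3)=C[C@H]12`) gives 350 nM as its result. Compound 2 therefore holds the lower of the two numbers, with a gap beyond the usual scatter. These two compounds differ in more than one place, so the gap cannot be tied to any single group. Compound 3 (`CC(C)[C@H]1CC[C@@]2(CO2)[C@H]2C(=O)OCC(C(=O)OCc3ccc(-c4ccc([N+](=O)[O-])cc4)o3)=C[C@H]12`) matches compound 2 except at one spot, turning phenyl to 4-nitrophenyl (nitro in place of hydrogen on an aromatic carbon). Among the compounds with values here, no measured pair shows what a single change of this kind does, so any expectation here is cautious. The estimate is a small move a 1.2-fold lower number from compound 2 to compound 3 (0.07 log units; within the scatter) that stays within the usual scatter. Compound 3 is expected at 300 nM with an estimated range of 100 nM to 900 nM on this measure.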

Compound 3, half-maximal inhibitory concentration: 450 nM
For compound 3 the middle estimate is 1.5-fold (0.18 log units) below the measured one; the range from low to high includes it.
By their numbers in this assay, from the lowest: compounds 2 and 3 (each within the scatter of the next); then compound 1.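

Within the data shown here, the first single change can now be read: in this assay, placing nitro in place of hydrogen on the phenyl ring, para to a large group, gives a 1.3-fold higher number from compound 2 to compound 3 (0.11 log units; within the scatter). On this read-out, compound 2 and compound 3 therefore cannot be told apart, so this position can carry the 4-nitrophenyl group as well as the plain phenyl without a difference beyond the scatter. No measurement at hand bears on the reason for this result.

As far as these compounds go, whether the same holds for a different group at this position, such as an amine or a carboxylic acid, remains open. Also open is which of the several differences between compound 1 and compound 2 accounts for the gap between them, since that pair cannot be read as a single step.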